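Methoxy in place of hydroxy on compound 3

The source may report more compounds than this note shows. Statements on the series, on what has been measured and on what is new or still open speak of the compounds shown alone.

compound 1 `N#Cc1cnc(NCc2cnccc2C(F)(F)F)cc1N[C@H]1CC[C@H](O)CC1`: 25%
compound 2 `CO[C@H]1CC[C@@H](Nc2cc(NCc3cnccc3C(F)(F)F)ncc2C#N)CC1`: 1%
compound 3 `N#Cc1cnc(NCc2cnccc2C(F)(F)F)cc1NC[C@H]1CC[C@@H](O)CC1`: 18%

In an ADME assay on S9 fraction from liver (Rattus norvegicus) for metabolic stability, with a stated time of 1 h (a lower number here means that less of the compound is left, a higher number that more of the compound is left), compound 3 gives 18%. Two steps place it: a number 7 percentage points lower from compound 1 to compound 3 (within the scatter), and a number 17 percentage points higher from compound 2 to compound 3 (beyond the scatter).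

Compound 4 `CO[C@H]1CC[C@@H](CNc2cc(NCc3cnccc3C(F)(F)F)ncc2C#N)CC1` differs from compound 3 by methyl in place of hydrogen on an oxygen on a saturated carbon. The same hydroxy to methoxy change has been measured only once, on 4-hydroxycyclohexyl: a number 24 percentage points lower from compound 1 to compound 2 (beyond the scatter). That step left compound 2 at 1%. From compound 3 at 18%, a somewhat smaller step in the same direction is the most that can be expected. The expected step is a number 14 percentage points lower from compound 3 to compound 4 (beyond the scatter). Compound 4 is estimated at 4%, with an expected range of 0% to 12%.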

Compound 4, percent of the compound remaining: 2%
Compound 4: the middle estimate sits 2 percentage points above what was measured; measured number inside the range.
By their numbers in this assay, from the lowest: compounds 2 and 4 (each within the scatter of the next); then compounds 3 and 1 (each within the scatter of the next).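

In this assay the hydroxy to methoxy change also lowers the number on the (4-hydroxycyclohexyl)methyl group, with a number 16 percentage points lower from compound 3 to compound 4 (beyond the scatter) here as well as on 4-hydroxycyclohexyl. Among the methoxy compounds, the two groups on the nitrogen stay within the scatter, with a number 1 percentage points higher from compound 2 to compound 4 (within the scatter) so both sit low. Taking both changes together gives a number 23 percentage points lower from compound 1 to compound 4 (beyond the scatter) and, in these four compounds, the oxygen's methyl, rather than the (4-methoxycyclohexyl)methyl group, tracks the low numbers. Going by these compounds, it remains open whether an amine or a carboxylic acid in place of hydroxy would behave like hydroxy or like methoxy. Nothing shown gives a reason for these steps.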